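The source may hold more compounds than are shown below. What is called first, only, known or untested is meant among the compounds shown, and "the series" means these compounds.

Measured so far:
compound 1 `CC(=O)c1ccc2c(c1)/C(=C/c1cccc(OCc3cn(Cc4ccccc4)nn3)c1)C(=O)N2` — in a functional assay on PC-3 cells (Homo sapiens) for inhibition, read by MTT assay, with a stated time of 48 h (on this read-out higher numbers stand for weaker inhibition and lower numbers for stronger inhibition), compound 1 gives > 50000 nM
compound 2 `COc1ccc(Cc2ccc3c(c2)/C(=C\c2cccc(OCc4cn(Cc5ccccc5)nn4)c2)C(=O)N3)cc1` — in this assay compound 2 gives 32200 nM

Compound 1 stands at a limit of this assay, not a number: the limit of > 50000 nM in this assay, at which 1 of the 2 values shown sits. Among the measured compounds shown here, the single number in the set is thus that of compound 2, 32200 nM. Compound 3 `COc1ccc(Cc2ccc3c(c2)/C(=C/c2cccc(OCc4cn(Cc5ccccc5)nn4)c2)C(=O)N3)cc1` keeps every atom and bond of compound 2: the two compounds have the same atoms and bonds and differ only in configuration as drawn: 1 of 1 stereo elements differ; a double bond is drawn E in compound 2 and Z in compound 3. For the measured compounds named here, no measured pair differs in geometry alone, so there is no step to lean on; a change of this kind is expected to shift this assay by little, in no fixed direction, and not beyond the scatter. Compound 3 is therefore estimated at 28000 nM (range 8000 nM to 60000 nM); the expected step is a 1.2-fold lower number from compound 2 to compound 3 (0.06 log units; within the scatter).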

Compound 3, half-maximal inhibitory concentration: > 50000 nM
Compound 3: a limit, no number; the forecaster's own chance of this, stated with the estimate: 25%; middle value at least 1.7-fold (0.25 log units) from the limit.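

Double-bond geometry can now be read on its own in this assay, as an at least 1.5-fold higher number from compound 2 to compound 3 (0.19 log units; that floor lies within the scatter), and that figure is only a floor. Compound 3 gives > 50000 nM, which is a limit and not a number. With limits on both sides, the step for 4-methoxybenzyl in place of acetyl on an aromatic carbon cannot be read: the limit of > 50000 nM in this assay, at which 2 of the 3 values shown sit.

Going by these compounds, how far the true step for the geometry change extends past that floor stays open. Also open, on these data alone, is whether an amine or a carboxylic acid in place of 4-methoxybenzyl on that aromatic carbon would give a number in either geometry.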